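Aryl variation on the sulfonyl sulfur of the series

A few compounds are considered here, and "the series" means these few. Any claim that something is new, unique, unknown or untested is made for them only; others in the source may bear on it.

Three compounds share one core and differ only in the aryl group carried by the sulfonyl sulfur. Compound 1 `COc1n[nH]c2ncc(-c3cn(-c4c(F)ccc(NS(=O)(=O)c5cccc(Cl)c5)c4F)nn3)cc12` gives 1.9 nM in an assay on Sf9 cells for inhibition of mitogen-activated protein kinase kinase kinase 20 (Homo sapiens), read by ADP-Glo, with a stated time of 30 min; on this read-out higher numbers stand for weaker inhibition and lower numbers for stronger inhibition. Compound 2 `COc1n[nH]c2ncc(-c3cn(-c4c(F)ccc(NS(=O)(=O)c5ccccc5)c4F)nn3)cc12` gives 3.8 nM in this assay, and compound 3 `COc1n[nH]c2ncc(-c3cn(-c4c(F)ccc(NS(=O)(=O)c5cccc(-c6ccccc6)c5)c4F)nn3)cc12` gives 4 nM. The step of a 2.0-fold higher number from compound 1 to compound 2 (0.30 log units; within the scatter) stays within the scatter, while a 2.1-fold higher number from compound 1 to compound 3 (0.32 log units; beyond the scatter) is modest but beyond it; a 1.1-fold higher number from compound 2 to compound 3 (0.02 log units; within the scatter) is again within the scatter. Compound 3 thus carries the highest number of the three, separated from compound 2 by a gap within the scatter and from compound 1 by a gap just beyond it.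

Compound 4 `COc1n[nH]c2ncc(-c3cn(-c4c(F)ccc(NS(=O)(=O)c5cccc6ccccc56)c4F)nn3)cc12` is not yet measured. It differs from compound 3 by naphthalen-1-yl in place of 3-phenylphenyl on a sulfonyl sulfur. Among the compounds with values here, the steps that bear on this change are those at the same sulfonyl aryl, a 1.1-fold higher number from compound 2 to compound 3 (0.02 log units; within the scatter) and a 2.1-fold higher number from compound 1 to compound 3 (0.32 log units; beyond the scatter), which together show that exchanging one group for another at this sulfur has so far moved the number only modestly in either direction. The exchange to naphthalen-1-yl is therefore expected to give no step beyond the scatter, no change at the digits printed from compound 3 to compound 4 (within the scatter). Compound 4 is estimated at 4 nM, with a range from 1.5 nM to 11 nM.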

Compound 4, half-maximal inhibitory concentration: 4.2 nM
Compound 4: the middle estimate sits 1.1-fold (0.02 log units) below what was measured; measured number inside the range.
By their numbers in this assay, from the lowest: compounds 1, 2, 3 and 4 (each within the scatter of the next, the first and the last beyond it).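

Placing naphthalen-1-yl on a sulfonyl sulfur in place of 3-phenylphenyl gives a 1.1-fold higher number from compound 3 to compound 4 (0.02 log units; within the scatter) in this assay, and placing it there in place of phenyl gives a 1.1-fold higher number from compound 2 to compound 4 (0.04 log units; within the scatter), so this second two-ring aryl group also cannot be told apart from the plain phenyl group. The comparison with 3-phenylphenyl also shows that going to the lower heavy-atom count of naphthalen-1-yl, with 2 six-membered aromatic rings on both sides, leaves the read-out within the scatter. Within the data shown here, the only new step beyond the scatter is a 2.2-fold higher number from compound 1 to compound 4 (0.34 log units; beyond the scatter), which is modest and of similar size to a 2.1-fold higher number from compound 1 to compound 3 (0.32 log units; beyond the scatter), and no measurement on hand accounts for either step or for the flat response among the other groups.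

The aryl groups shown carry only carbon apart from the chloro substituent, so it remains open whether a phenyl ring bearing an amine or a carboxylic acid would hold the number in this narrow band. The same question applies to a saturated group on the sulfonyl sulfur, such as cyclohexyl or a longer alkyl chain.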